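Compound 4 expected from compound 3 and a chloro step

The source may hold more compounds than are shown below. What is called first, only, known or untested is meant among the compounds shown, and "the series" means these compounds.

Of the compounds shown here, three on a shared core have been measured. In a functional assay, tested at 200 ug/mL (a higher number here means a weaker effect of the compound at the concentration tested, a lower number a stronger effect), compound 1 `CCOC(=O)C1=C(C)N(c2ccccc2)C=CC1c1ccccc1` gives -34%. In this assay compound 2 `CCOC(=O)C1=C(C)N(c2ccc(Cl)cc2)C=CC1c1ccccc1` gives -37.4%, and the step of a number 3.4 percentage points lower from compound 1 to compound 2 (within the scatter) lies within the scatter. In this assay compound 3 `CC1=C(C(=O)OC(C)(C)C)C(c2ccccc2)C=CN1c1ccccc1` gives -52.9%, the lowest of the three numbers; the step of a number 18.9 percentage points lower from compound 1 to compound 3 (beyond the scatter) is beyond the scatter, and the gap to compound 2 is also beyond it.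

Compound 4 `CC1=C(C(=O)OC(C)(C)C)C(c2ccccc2)C=CN1c1ccc(Cl)cc1` differs from compound 3 by chloro in place of hydrogen on an aromatic carbon. For the measured compounds named here, the one measured step that bears on this change is the step from compound 1 to compound 2, which carried the same replacement on the same kind of ring and stayed within the scatter. Nothing in the measured set suggests that this change behaves differently on the core of compound 3. He therefore expects in this assay no step beyond the scatter, with the estimated step of a number 2.1 percentage points lower from compound 3 to compound 4 (within the scatter). For compound 4 the estimate is -55%, in a range from -68% to -42%.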

Compound 4, a percentage reported as activity, at one concentration (the size of the read-out at that concentration, not a potency): -48%
Estimate against measurement, compound 4: 7 percentage points below, within the range that was stated.
By their numbers in this assay, from the lowest: compounds 3 and 4 (each within the scatter of the next); then compounds 2 and 1 (each within the scatter of the next).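

In this assay, the change from phenyl to 4-chlorophenyl now stands on a second core, where it gives a number 4.9 percentage points higher from compound 3 to compound 4 (within the scatter), and its two readings agree: the same change on two cores in this assay, a number 3.4 percentage points lower (within the scatter) from compound 1 to compound 2 and a number 4.9 percentage points higher (within the scatter) from compound 3 to compound 4, 8.3 percentage points apart, within the scatter of two such steps The change to tert-butyl in place of ethyl now also has a second reading, with the chloro group present, at a number 10.6 percentage points lower from compound 2 to compound 4 (beyond the scatter), and these two readings agree as well: the same change on two cores in this assay, a number 18.9 percentage points lower (beyond the scatter) from compound 1 to compound 3 and a number 10.6 percentage points lower (beyond the scatter) from compound 2 to compound 4, 8.3 percentage points apart, within the scatter of two such steps Among these four compounds, tert-butyl in place of ethyl moves the number beyond the scatter in both pairs, while chloro in place of hydrogen does so in neither.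

The compounds shown leave open what an amine or a carboxylic acid would do on this aromatic carbon. They also leave open how a longer chain on the oxygen would compare with ethyl and tert-butyl.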